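The source may hold more compounds than are shown below. What is called first, only, known or untested is meant among the compounds shown, and "the series" means these compounds.

In a functional assay on COLO1 cells (Homo sapiens) for inhibition (a lower number here means a stronger inhibitor, a higher number a weaker inhibitor), compound 2 (`Cc1nc2c(s1)C(=O)C=C(Nc1ccc(O)cc1)C2=O`) gives 1.85 ug/mL as the lower of the two numbers, while compound 1 (`Cc1nc2c(s1)C(=O)C=C(Nc1ccc(Br)cc1)C2=O`) gives 6.57 ug/mL on the higher side. Compound 3 (`CCOc1ccc(NC2=CC(=O)c3sc(C)nc3C2=O)cc1`) differs from compound 2 by ethyl in place of hydrogen on an oxygen on an aromatic ring (hydroxy to ethoxy). Going by the values given here, the one measured step at this group is a 3.6-fold lower number from compound 1 to compound 2 (0.55 log units; beyond the scatter) (hydroxy in place of bromo), modest and beyond the scatter. Among the compounds with values here, no measured compound carries ethoxy, so that step offers only a rough guide to size. A modest move to a higher number in this assay is expected, estimated as a 1.9-fold higher number from compound 2 to compound 3 (0.28 log units; within the scatter) overall. For compound 3 the estimated value is 3.5 ug/mL (range 1.3 ug/mL to 9 ug/mL) in this series.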

Compound 3, half-maximal inhibitory concentration: 2.09 ug/mL
Beside the measured number, compound 3's estimate is 1.7-fold (0.22 log units) above it; the range from low to high includes it.
By their numbers in this assay, from the lowest: compounds 2 and 3 (each within the scatter of the next); then compound 1.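

In this assay hydroxy and ethoxy cannot be told apart at this position (a 1.1-fold higher number from compound 2 to compound 3 (0.05 log units; within the scatter)), so the hydrogen on this oxygen can give way to ethyl with no shift beyond the scatter. Ethoxy also separates from bromo (a 3.1-fold lower number from compound 1 to compound 3 (0.50 log units; beyond the scatter)), which makes compound 1 the outlier among the three compounds. No evidence bears on the reason for this result.

On these data alone, whether a longer chain on this oxygen would stay level with compound 2 and compound 3 remains open. So does whether an amine in place of the hydroxy would hold that level.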